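A branched ester in place of a straight one

This account rests on a few compounds, and the source may have more. Where it says the series, first, only, none or still open, it means among the compounds named here.

Values measured so far in a physicochemical assay for lipophilicity, using the shake flask method, in phosphate buffer, measured as octanol-water partition, with a stated time of 2 days, at pH 7.4 (a higher number here means a more lipophilic compound, a lower number a more polar compound), are these
- compound 1 (`CCOC(=O)c1cnc(N2CCN(C(=S)Nc3ccccc3)CC2)c(Cl)c1`) gives "not determined" (no result reported)
- compound 2 (`CCOC(=O)c1cnc(N2CC(NC(=O)NS(=O)(=O)c3ccccc3)C2)c(Cl)c1`) gives 0.8
- compound 3 (`CCCOC(=O)c1cnc(N2CCN(C(=O)NS(=O)(=O)c3ccc(Cl)s3)CC2)c(Cl)c1`) gives 1.6

Compound 3 at 1.6 holds the higher of the two available numbers. Compound 2 at 0.8 lies lower, by a gap beyond the usual scatter, while compound 1 offers no number for comparison.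

Compound 4 (`CC(C)OC(=O)c1cnc(N2CCN(C(=O)NS(=O)(=O)c3ccc(Cl)s3)CC2)c(Cl)c1`) has isopropyl in place of propyl on an oxygen next to a carbonyl group, so compound 3 and compound 4 have the same atoms, joined differently. No measured pair among these compounds shows a change of this kind, so the expectation rests on the structural change alone, anchored on compound 3 at 1.6 as its starting point. The expected step of a number 0.10 log units lower from compound 3 to compound 4 (within the scatter) in this assay is small and downward, not beyond the scatter. For compound 4 the expected value is 1.5, with an estimated range of 1.2 to 1.8 around it.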

Compound 4, distribution coefficient: 1.5
Compound 4: the middle estimate sits on the measured number at the digits printed, within the range that was stated.
By their numbers in this assay, from the lowest: compound 2; then compounds 4 and 3 (each within the scatter of the next).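

In this assay, isopropyl in place of propyl on an oxygen next to a carbonyl group gives a number 0.10 log units lower from compound 3 to compound 4 (within the scatter), the first step among these compounds that isolates a change in one place. Among these compounds, earlier comparisons could not do this, since compound 2 and compound 3 differ in more than one place. At this position, across this one pair, the straight and branched chains cannot be told apart by this measurement, although a single pair sets no general rule. Nothing available explains why the step is so small.

The compounds shown leave open how a longer chain such as butyl, or a carboxylic acid in place of the ester, would read at this position. They also leave open whether the same swap would give a similar step on the core of compound 2.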